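This account rests on a few compounds, and the source may have more. Where it says the series, first, only, none or still open, it means among the compounds named here.

For the measured compounds named here, only two compounds sharing one core have so far been taken into an ADME assay on Vero cells (Chlorocebus sabaeus) for cytotoxicity, read by MTT assay, with a stated time of 72 h (on this read-out higher numbers stand for lower toxicity in this test and lower numbers for higher toxicity in this test), and neither gives a plain number. Compound 1 (`CC(C)c1ccc(C(Nc2ccc(C3(C)NC(=O)c4ccccc4N3)cc2)c2nnnn2C(C)(C)C)cc1`) reads > 400000 nM, which is a limit of the assay and not a number. For compound 2 (`COc1cc(C(Nc2ccc(C3(C)NC(=O)c4ccccc4N3)cc2)c2nnnn2C(C)(C)C)cc(OC)c1OC`) the result stands as "not determined" (no result reported), so compound 2 has no place on the scale. Compound 3 (`CC1(c2ccc(NC(c3ccc(Cl)cc3)c3nnnn3C(C)(C)C)cc2)NC(=O)c2ccccc2N1`) remains to be measured. The structural change is 4-chlorophenyl in place of 3,4,5-trimethoxyphenyl on a saturated chain carbon bound to an aromatic carbon and a nitrogen on an aromatic ring and it puts 4-chlorophenyl in place of 3,4,5-trimethoxyphenyl on a saturated chain carbon bound to an aromatic carbon and a nitrogen on an aromatic ring. Going by the values given here, no measured step between any two compounds is available to size this change. The expectation in this assay is therefore for no step beyond the usual scatter, in either direction. Among the compounds with values here, the one guide is compound 1, whose reading of > 400000 nM is again a limit. For compound 3 the half-maximal cytotoxic concentration is estimated at 400000 nM, with an expected range from 150000 nM to 600000 nM.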

Compound 3, half-maximal cytotoxic concentration: > 400000 nM
Compound 3: only a limit was reported; the forecaster's own chance of this, stated with the estimate: 70%; the middle value lies on the limit itself.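

In this assay no step can be read from compound 1 to compound 3, nor from compound 2, which has no reported result, to compound 3. Compound 1 and compound 3 each give a limit of the assay and not a number: the limit of > 400000 nM in this assay, at which 2 of the 3 values shown sit.

The compounds shown leave open whether chloro in place of isopropyl, or 4-chlorophenyl in place of 3,4,5-trimethoxyphenyl, alters the half-maximal cytotoxic concentration at all.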